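This account rests on a few compounds, and the source may have more. Where it says the series, first, only, none or still open, it means among the compounds named here.

In a functional assay on MGC-803 cells (Homo sapiens) for inhibition, read by MTT assay, with a stated time of 72 h (on this read-out lower numbers stand for stronger inhibition and higher numbers for weaker inhibition), compound 1 `Cc1cc(Nc2cc(-c3ccccc3)[nH]n2)n2nc(SCc3ccc([N+](=O)[O-])cc3)nc2n1` gives 4250 nM and stands among the three numbers in hand, within the scatter of each of the other two: compound 2 `Cc1cc(Nc2ccn(Cc3cccc4ccccc34)n2)n2nc(SCc3ccc(Br)cc3)nc2n1` gives 3240 nM and compound 3 `Cc1cc(Nc2cc(C(C)(C)C)[nH]n2)n2nc(SCc3ccc(Br)cc3)nc2n1` gives 5620 nM on the same read-out. The next compound to be tested is compound 4 `C#CCSc1nc2nc(C)cc(Nc3cc(-c4ccccc4)[nH]n3)n2n1` which carries ethynyl in place of 4-nitrophenyl on a saturated chain carbon bound to a sulfur and so reads as 4-nitrobenzyl to propargyl. Going by the values given here, no measured pair isolates this change, and all three measured compounds keep an aromatic ring at that place, so the expected direction rests on little. A small rise in the number in this assay is expected, meaning somewhat weaker inhibition, hardly beyond the scatter. The expected step is a 1.4-fold higher number from compound 1 to compound 4 (0.15 log units; within the scatter) as an estimate only. Compound 4 is estimated at 6000 nM with an expected range from 2000 nM to 18000 nM for repeated measurements.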

Compound 4, half-maximal inhibitory concentration: 13400 nM
Beside the measured number, compound 4's estimate is 2.2-fold (0.35 log units) below it; measured number inside the range.
By their numbers in this assay, from the lowest: compounds 2, 1 and 3 (each within the scatter of the next); then compound 4.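

In this assay, going by these compounds alone, the pair compound 1 and compound 4 gives the first reading of a single change at this position: 4-nitrobenzyl to propargyl, with all else held, is a 3.2-fold higher number from compound 1 to compound 4 (0.50 log units; beyond the scatter), so inhibition weakens. The position is therefore not indifferent to its substituent, and the shared core with the phenyl-bearing amino substituent does not keep the number unchanged when the six-membered aromatic ring and nitro group leave together. No measurement here explains the step.

Because this one step changes the ring, the nitro group and the size of the substituent at once, it cannot show which of these matters. From the compounds shown here alone, an unsubstituted benzyl, a saturated propyl chain or a benzyl carrying a carboxylic acid would separate these possibilities, and whether the step holds on other amino substituents remains open.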